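The source may hold more compounds than are shown below. What is called first, only, known or untested is meant among the compounds shown, and "the series" means these compounds.

Measured compounds:
compound 1, `CN(C)C(=O)c1cc2cnc(Nc3ccc(C(=O)NCCCCN=C=S)cc3)nc2n1C1CCCC1`, 30.2%
compound 2, `CN(C)C(=O)c1cc2cnc(Nc3ccc(C(=O)NCCCN=C=S)cc3O)nc2n1C1CCCC1`, 55.9%

Of the compounds shown here, two have been measured in a functional assay on A549 cells (Homo sapiens) for inhibition, read by CCK-8 assay, with a stated time of 72 h, tested at 1 uM; on this read-out higher numbers stand for a stronger effect at the one concentration tested and lower numbers for a weaker effect. Compound 1 gives 30.2% in this assay, while compound 2 gives 55.9%, the higher of the two numbers, and the gap between them lies beyond the usual scatter. The two compounds differ from each other in more than one place, so no single cause for that gap can be read from these numbers.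

Compound 3, `CN(C)C(=O)c1cc2cnc(Nc3ccc(C(=O)NCCCCN=C=S)cc3O)nc2n1C1CCCC1`, has not yet been measured. It differs from compound 2 in one place: a group of 4 heavy atoms (2 carbon, 1 nitrogen, 1 sulfur; no ring) in place of a group of 3 heavy atoms (1 carbon, 1 nitrogen, 1 sulfur; no ring), on a saturated chain carbon, three bonds along the chain from an amide-type nitrogen. The entering group is the same one that compound 1 carries on its chain, so compound 3 sits between the two measured compounds in structure.

Among the measured compounds shown here, because compound 1 gives 30.2% and compound 2 gives 55.9%, the only guidance available points in opposite directions depending on which part of the change matters, and a modest downward step is expected, a number 10.9 percentage points lower from compound 2 to compound 3 (beyond the scatter). The estimate for compound 3 in this assay is 45%, with a range from 25% to 65%.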

Compound 3, a percentage reported as inhibition, at one concentration (the size of the read-out at that concentration, not a potency): 30.3%
For compound 3 the middle estimate is 14.7 percentage points above the measured one, and the stated range covers the measured number.
By their numbers in this assay, from the lowest: compounds 1 and 3 (each within the scatter of the next); then compound 2.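

In this assay, the group of 4 heavy atoms in place of the group of 3 heavy atoms, on a saturated chain carbon, three bonds along the chain from an amide-type nitrogen, gives a number 25.6 percentage points lower from compound 2 to compound 3 (beyond the scatter), so this single change on the chain is enough by itself to produce a clear drop. Hydroxy in place of hydrogen on an aromatic carbon, with the group of 4 heavy atoms on the chain, gives a number 0.1 percentage points higher from compound 1 to compound 3 (within the scatter), so with this chain group the hydroxy makes no difference that can be told from the usual scatter. Nothing measured on these compounds speaks to the reason for either step.

Whether hydroxy matters when the chain carries the group of 3 heavy atoms stays open, as the compounds shown include no partner of compound 2 with hydrogen on that aromatic carbon. Also open, as far as these compounds go, is whether a longer chain, or an amine or a carboxylic acid in place of these groups on the saturated chain carbon, would give a number closer to that of compound 2 or of compound 3.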